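This account rests on a few compounds, and the source may have more. Where it says the series, first, only, none or still open, it means among the compounds named here.

Measured in a functional assay on U-251 cells (Homo sapiens); a lower number here means a stronger inhibitor of growth, a higher number a weaker inhibitor of growth:
- compound 1 `COc1cccc(-c2cc(O)c3c(C)cc(C)nc3n2)c1`: 170 nM
- compound 2 `COc1cccc(-c2cc(O)c3cc(C)cnc3n2)c1`: 44.7 nM
- compound 3 `COc1cccc(-c2cc(O)c3c(C)ccnc3n2)c1`: 58.9 nM

Compound 3, at 58.9 nM, cannot be told apart from compound 2, at 44.7 nM, since the two lie within the scatter of each other. Compound 1, at 170 nM, shows a clearly higher number than either.

The next compound to be tested is compound 4 `COc1cccc(-c2cc(O)c3cccnc3n2)c1`, which differs from compound 3 by one change: hydrogen in place of methyl on an aromatic carbon. Hydrogen stands in place of methyl on an aromatic carbon, opposite the ring nitrogen.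

Among the measured compounds shown here, only one measured step bears on this directly. It is the same kind of replacement, made on a different carbon of the core, and it gave a 2.9-fold lower number from compound 1 to compound 3 (0.46 log units; beyond the scatter). That single modest step suggests that losing the remaining methyl may lower the number again in this assay. One step at another carbon is a weak guide, however, so a smaller change is expected here, probably not beyond the scatter.

The expected step is a 1.5-fold lower number from compound 3 to compound 4 (0.17 log units; within the scatter).

For compound 4 the estimated value is 40 nM, with an expected range of 14 nM to 115 nM.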

Compound 4, concentration for 50% growth inhibition: 55 nM
Compound 4: the middle estimate sits 1.4-fold (0.14 log units) below what was measured, and the stated range covers the measured number.
By their numbers in this assay, from the lowest: compounds 2, 4 and 3 (each within the scatter of the next); then compound 1.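

In this assay, the methyl opposite the ring nitrogen carries no measurable weight once it is the only methyl on the core: the step is a 1.1-fold lower number from compound 3 to compound 4 (0.03 log units; within the scatter), which leaves compound 3 and compound 4 indistinguishable. Compound 2, with its single methyl on a different aromatic carbon, gives the same picture, with a 1.2-fold higher number from compound 2 to compound 4 (0.09 log units; within the scatter), so the core without any methyl holds up as well as either core with one. Replacing methyl with hydrogen therefore does not give a constant shift across these cores, and of the steps shown only the one starting from compound 1, which carries two methyls on the core, lies beyond the scatter: the same change on two cores in this assay, a 2.9-fold lower number (0.46 log units; beyond the scatter) from compound 1 to compound 3 and a 1.2-fold higher number (0.09 log units; within the scatter) from compound 2 to compound 4, 3.6-fold (0.55 log units) apart, beyond the scatter of two such steps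

The compounds shown cover only methyl and hydrogen at this carbon, so it remains open whether an ethyl group, a chlorine atom or an amine there would also leave the number unmoved. On these data alone, all four compounds also share the same methoxy and hydroxyl groups, and whether this position stays as undemanding when either of those groups is replaced remains unknown.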